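Cytotoxicity notes on a fused-ring carbamate series

The source may report more compounds than this note shows. Statements on the series, on what has been measured and on what is new or still open speak of the compounds shown alone.

Measured so far in an ADME assay on Huh-7 cells (Homo sapiens) for cytotoxicity, read by MTT assay, with a stated time of 48 h; a higher number here means that more compound is tolerated, a lower number that less compound is tolerated:
compound 1 `Nc1ccc(CN2N=C(c3ccc(F)cc3)C3C=CC=CC3C2=O)cc1`, compound 1 gives > 80000 nM, which is a limit of the assay and not a number.
compound 2 `CN(C)CCCCOC(=O)Nc1ccc(Cn2nc(-c3cncnc3)c3ccccc3c2=O)cc1`, compound 2 gives 65300 nM.

Among the measured compounds shown here, compound 2 holds the only numerical value in this assay. The other result is a limit: the limit of > 80000 nM in this assay, at which 1 of the 2 values shown sits. For the measured compounds named here, no step between two measured compounds can be computed here, since compound 1 and compound 2 differ in more than one place.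

Compound 3 `CN(C)CCCCOC(=O)Nc1ccc(Cn2nc(-c3cccc(C#N)c3)c3ccccc3c2=O)cc1` is not yet measured. It differs from compound 2 in one place: 3-cyanophenyl in place of pyrimidin-5-yl on an aromatic carbon.

No measured step covers this change, so the size of its effect cannot be read from the shown numbers. The expectation is that the step from compound 2 to compound 3 in this assay, a 1.3-fold lower number from compound 2 to compound 3 (0.12 log units; within the scatter), stays within the usual scatter of repeated measurements, with a slight lean toward less compound being tolerated. On that basis compound 3 is estimated at 50000 nM, within a range from 20000 nM to 80000 nM in this assay.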

Compound 3, half-maximal cytotoxic concentration: 17200 nM
Compound 3: middle estimate off by 2.9-fold (0.46 log units), on the high side, outside the stated range (below it).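

Among the compounds shown here, replacing pyrimidin-5-yl with 3-cyanophenyl on this aromatic carbon gives the first step that can be read in this assay: a 3.8-fold lower number from compound 2 to compound 3 (0.58 log units; beyond the scatter). With the rest of the molecule unchanged, this shows that the group at this position can move the tolerated concentration beyond the usual scatter, at least for this pair. The change swaps a six-membered aromatic ring with 2 hetero atoms for one of carbon only that carries a triple bond, but nothing measured here gives a reason for the step.

This single step cannot separate the loss of the ring nitrogens from the arrival of the nitrile, a question that a plain phenyl or a pyridin-3-yl in the same place would address. It also leaves open whether the step would hold with another carbamate side chain, such as one with a morpholine in place of the dimethylamino group, and compound 1 cannot help there, as its result is a limit and it differs from compound 2 in more than one place.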